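The source may hold more compounds than are shown below. What is called first, only, known or untested is meant among the compounds shown, and "the series" means these compounds.

Measured so far in an assay for inhibition of alkaline phosphatase, tissue-nonspecific isozyme (Homo sapiens), read by spectrophotometry, with stated times of 10 min and 20 min; on this read-out lower numbers stand for stronger inhibition and higher numbers for weaker inhibition: compound 1 `O=C1/C(=C/c2ccccc2)NS(=O)(=O)c2ccccc21` gives 660 nM. Compound 2 `O=C1/C(=C/c2ccccc2Br)NS(=O)(=O)c2ccccc21` sits at the assay limit of > 200000 nM, a limit rather than a number.

Compound 2 thus stands at the weak end of what this assay reports (the limit of > 200000 nM in this assay, at which 1 of the 2 values shown sits). The change to compound 3 `O=C1/C(=C/c2cccc(O)c2)NS(=O)(=O)c2ccccc21` is 3-hydroxyphenyl in place of 2-bromophenyl on a double-bonded chain carbon bound to a double-bonded ring carbon. For the measured compounds named here, the one measured step that bears on it is an at least 300-fold higher number from compound 1 to compound 2 (2.48 log units; beyond the scatter), where placing the bromine on the ring weakened inhibition far beyond the scatter. On these data alone, compound 3 carries no bromine, so the expected step largely undoes that loss; the hydroxy group has not been tested, and its own contribution is unknown. The expected step is therefore an at least 130-fold lower number from compound 2 to compound 3 (2.12 log units; beyond the scatter) in this assay, back toward the level of compound 1. The estimate for compound 3 is 1500 nM, with a range from 300 nM to 20000 nM.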

Compound 3, half-maximal inhibitory concentration: 3570 nM
For compound 3 the middle estimate is 2.4-fold (0.38 log units) below the measured one; low and high end bracket the measured number.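

In this assay, 3-hydroxyphenyl in place of 2-bromophenyl on a double-bonded chain carbon bound to a double-bonded ring carbon gives an at least 56-fold lower number from compound 2 to compound 3 (1.74 log units; beyond the scatter), so a substituted phenyl at this place does not have to abolish inhibition. The size of that step is only a lower bound, as compound 2 gives a limit and not a number: the limit of > 200000 nM in this assay, at which 1 of the 3 values shown sits. The hydroxy group still has a cost, with its addition giving a 5.4-fold higher number from compound 1 to compound 3 (0.73 log units; beyond the scatter), which leaves the unsubstituted compound 1 the stronger of the pair.

The compounds shown do not separate the effect of the group from that of its ring position, so it remains open how 3-bromophenyl or 2-hydroxyphenyl would compare. On these data alone, how an amine or a carboxylic acid on this phenyl ring would fare is also open.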